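Back from a branched alkyl to an aryl group

The compounds below may be only part of what the source reports. "The series", "measured", "known", "first", "only" and "open" are said of these compounds alone.

For the measured compounds named here, compound 3 `CCC(CC)c1ccc2c(NCCCNCc3cccc(OC)c3O)ccnc2c1` gives 23 10^-6 cm/s in an ADME assay for permeability, using PAMPA, with a stated time of 30 min, at pH 7.4 (on this read-out lower numbers stand for lower permeability and higher numbers for higher permeability), the lowest of the three numbers measured so far. Compound 1 `COc1cccc(CNCCCNc2ccnc3cc(Oc4ccccc4)ccc23)c1O` gives 317 10^-6 cm/s in this assay, and compound 2 `COc1cccc(CNCCCNc2ccnc3cc(Oc4cccc(N(C)C)c4)ccc23)c1O` gives 317 10^-6 cm/s in this assay. Between those two there is no change at the digits printed from compound 1 to compound 2 (within the scatter). Compound 3 stands well apart from both: a 14-fold lower number from compound 1 to compound 3 (1.14 log units; beyond the scatter), and a 14-fold lower number from compound 2 to compound 3 (1.14 log units; beyond the scatter).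

Compound 4 `COc1cccc(CNCCCNc2ccnc3cc(-c4ccc(C(F)(F)F)cc4)ccc23)c1O` has not yet been measured in this assay. It differs from compound 3 in one place: 4-(trifluoromethyl)phenyl in place of pentan-3-yl on an aromatic carbon. The two large steps already seen bear directly on this change. In a 14-fold lower number from compound 1 to compound 3 (1.14 log units; beyond the scatter) the pentan-3-yl group arrived in place of phenoxy, and in a 14-fold lower number from compound 2 to compound 3 (1.14 log units; beyond the scatter) it arrived in place of 3-(dimethylamino)phenoxy; in both the number fell by a large margin. The step to compound 4 runs the other way, taking the pentan-3-yl group out and putting an aromatic ring back in. A large rise is therefore expected, though 4-(trifluoromethyl)phenyl matches neither phenoxy nor 3-(dimethylamino)phenoxy exactly, so the range is kept wide. For compound 4 the expected value in this assay is 200 10^-6 cm/s, between 60 10^-6 cm/s and 450 10^-6 cm/s. The expected step is an 8.7-fold higher number from compound 3 to compound 4 (0.94 log units; beyond the scatter).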

Compound 4, apparent permeability: 237 10^-6 cm/s
For compound 4 the middle estimate is 1.2-fold (0.07 log units) below the measured one; the measured number falls inside the stated range.
By their numbers in this assay, from the lowest: compound 3; then compounds 4, 1 and 2 (each within the scatter of the next).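

Putting 4-(trifluoromethyl)phenyl on this aromatic carbon gives a 10-fold higher number from compound 3 to compound 4 (1.01 log units; beyond the scatter) in this assay and so reverses the fall that came with pentan-3-yl. The earlier high numbers belonged only to phenoxy groups, yet this aryl group is joined directly, with no oxygen link, and carries a trifluoromethyl group, and it still stands level with them, with a 1.3-fold lower number from compound 1 to compound 4 (0.13 log units; within the scatter) and a 1.3-fold lower number from compound 2 to compound 4 (0.13 log units; within the scatter) as the two comparisons. Across these four compounds, then, the oxygen link is not needed for a high number at this place, and the one compound that stands apart is compound 3, whose group is the only one without a ring; no compound shown goes against this pattern.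

Going by these compounds, what stays open is whether the aromatic ring itself counts or simply the larger group, a question that a saturated ring such as cyclohexyl at this place would help to separate, and whether a carboxylic acid on the ring would keep the number where it is. Nothing measured here gives a reason for the gap between compound 3 and the other three.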